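This account rests on a few compounds, and the source may have more. Where it says the series, first, only, none or still open, it means among the compounds named here.

Compound 1 `CCS(=O)(=O)Nc1ccc(NC(=O)c2ccc(Cl)cc2)cc1C` and compound 2 `CCS(=O)(=O)Nc1ccc(NC(=O)c2ccc(C#N)cc2)cc1C` share one core, and compound 3 `COc1cc(NC(=O)c2ccc(Cl)cc2)ccc1NS(=O)(=O)C(F)(F)F` and compound 4 `COc1cc(NC(=O)c2ccc(C#N)cc2)ccc1NS(=O)(=O)C(F)(F)F` share another. In an ADME assay on RAW264.7 cells (Mus musculus) for cytotoxicity, read by MTT assay, with a stated time of 48 h (a higher number here means a weaker inhibitor, a lower number a stronger inhibitor), compound 1 gives 68700 nM. In this assay compound 2 gives 109000 nM. The change from compound 1 to compound 2 is cyano in place of chloro on an aromatic carbon and it made a step of a 1.6-fold higher number from compound 1 to compound 2 (0.20 log units; within the scatter). In this assay compound 3 gives 108000 nM, a number that sits within the scatter of both compound 1 and compound 2. The difference between the core of compound 3 and the core of compound 1 is not broken down here. Compound 4 is related to compound 3 by the same change: cyano in place of chloro on an aromatic carbon. The place of the change reads the same in both pairs, so this is the same change, made on the second core.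

Compound 4 has not yet been measured in this assay. The step from compound 3 to compound 4 is expected to be a 1.4-fold higher number from compound 3 to compound 4 (0.14 log units; within the scatter), because the same change gave a 1.6-fold higher number from compound 1 to compound 2 (0.20 log units; within the scatter) and that step stayed within the scatter. The expectation rests on one earlier pair only, and on the second core nothing is known about how the change will carry over. For compound 4 the estimated number in this assay is 150000 nM, with the expected range running from 70000 nM to 320000 nM.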

Compound 4, half-maximal inhibitory concentration: > 250000 nM
Compound 4: a limit, no number (the forecaster's own chance of this, stated with the estimate: 25%); middle value at least 1.6-fold (0.22 log units) from the limit.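

Compound 4 carries no number in this assay, only a limit of the assay: the limit of > 250000 nM in this assay, at which 1 of the 4 values shown sits. On the second core, cyano in place of chloro gives an at least 2.3-fold higher number from compound 3 to compound 4 (0.36 log units; beyond the scatter), a step beyond the scatter, whereas on the first core the same change gives a 1.6-fold higher number from compound 1 to compound 2 (0.20 log units; within the scatter), a step within it. This places a clear step on the second core only, but it does not show that the change acts differently on the two cores, as one side of the second step remains unbounded and only two pairs are available: the same change on two cores in this assay, a 1.6-fold higher number (0.20 log units; within the scatter) from compound 1 to compound 2 and an at least 2.3-fold higher number (0.36 log units; beyond the scatter) from compound 3 to compound 4; the limit leaves it open whether they differ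

The compounds shown leave open how the series would respond to other groups at this place on the aromatic ring, para to a large group, such as an amine, a carboxylic acid or a longer chain in place of chloro or cyano. They also leave open which part of the difference between the two cores bears on the size of the step, and whether the change from 4-chlorophenyl to 4-cyanophenyl would behave alike on any further core.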